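The source may report more compounds than this note shows. Statements on the series, on what has been measured and on what is new or still open speak of the compounds shown alone.

Notes on the series. Compound 3 `O=C1NC(=O)C(c2c(-n3cccn3)[nH]c3ccccc23)=C1Br` and compound 2 `Cc1ccc2[nH]c(-n3cccn3)c(C3=C(Br)C(=O)NC3=O)c2c1` share one core; compound 1 `O=C1CC(c2c(-c3ccc[nH]3)[nH]c3ccccc23)C(=O)N1` carries a different core, and the difference between the two cores is not broken down here. In a functional assay on B16-F10 cells (Mus musculus) for cytotoxicity, read by MTT assay, with a stated time of 72 h (a lower number here means a stronger inhibitor, a higher number a weaker inhibitor), compound 1 gives 2000 nM, compound 2 gives 8000 nM and compound 3 gives 13000 nM. Compound 1 stands lowest of the three, with compound 2 nearest and compound 3 furthest, both gaps beyond the scatter.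

One structural change occurs twice in the set. Between the two compounds that share a core it is methyl in place of hydrogen on an aromatic carbon, and the step it made is a 1.6-fold lower number from compound 3 to compound 2 (0.21 log units; within the scatter), which lies within the scatter. The unmeasured compound 4 `Cc1ccc2[nH]c(-c3ccc[nH]3)c(C3CC(=O)NC3=O)c2c1` carries the same change on the core of compound 1: methyl in place of hydrogen on an aromatic carbon. The place is the same word for word in both cases, so this is the same change made on two cores.

On that basis the number for compound 4 is expected to sit close to that of compound 1, perhaps a little lower. In this assay the expected step is a 1.3-fold lower number from compound 1 to compound 4 (0.12 log units; within the scatter), resting on the measured 1.6-fold lower number from compound 3 to compound 2 (0.21 log units; within the scatter). Whether the change carries over from one core to the other rests on a single measured pair, so the range is kept wide. For compound 4 the estimate is 1500 nM, between 600 nM and 4500 nM.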

Compound 4, half-maximal inhibitory concentration: 500 nM
The estimate for compound 4 lay 3.0-fold (0.48 log units) above the measured number; measured number outside the range, below it.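

In this assay, methyl in place of hydrogen on an aromatic carbon on the core of compound 1 gives a 4.0-fold lower number from compound 1 to compound 4 (0.60 log units; beyond the scatter), whereas the same change on the other core gave a step that stayed within the scatter. Set side by side, the two steps run in the same direction, and the gap between them does not exceed what two such steps can show by scatter alone: the same change on two cores in this assay, a 1.6-fold lower number (0.21 log units; within the scatter) from compound 3 to compound 2 and a 4.0-fold lower number (0.60 log units; beyond the scatter) from compound 1 to compound 4, 2.5-fold (0.39 log units) apart, within the scatter of two such steps

Among these compounds, this supports carrying the direction of the change from one core to the other, but it does not establish that the size of the step is the same on both cores or that it differs, since each core contributes only a single pair, and it says nothing about any third core.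

The compounds shown leave open whether the lower number on the core of compound 1 is particular to methyl or would also follow from a chlorine atom, a methoxy group or a longer chain such as ethyl on the same aromatic carbon. They also leave open whether the step seen on these mouse cells would appear in any other cell line.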